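Changing the Group on the Ring Nitrogen of Compound 1

The source may hold more compounds than are shown below. What is called first, only, known or untested is meant among the compounds shown, and "the series" means these compounds.

Compound 1 `OC(Cc1ccccc1)CN1CCC(NCCSC(c2ccc(F)cc2)c2ccc(F)cc2)CC1` was tested in an assay on membranes from Cortex for displacement of a labelled ligand from Sigma non-opioid intracellular receptor 1 (Cavia porcellus), read by scintillation counting, with a stated time of 120 min (a higher number here means a weaker inhibitor, a lower number a stronger inhibitor), and gives 309 nM. Among the compounds with values here, of the three compounds measured so far it has the second highest number, though all three sit close together: compound 3 `O=C(c1cc2ccccc2o1)N1CCC(NCCSC(c2ccc(F)cc2)c2ccc(F)cc2)CC1` gives 304 nM, and compound 2 `[O-][S+](CCNC1CCN(CC(O)Cc2ccccc2)CC1)C(c1ccc(F)cc1)c1ccc(F)cc1` gives 351 nM, and the gaps between them fall within the usual scatter of such measurements.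

Compound 4 `Fc1ccc(C(SCCNC2CCN(Cc3cc4ccccc4[nH]3)CC2)c2ccc(F)cc2)cc1` has not yet been measured. It differs from compound 1 in a single place: 1H-indol-2-yl in place of 1-hydroxy-2-phenylethyl on a saturated chain carbon bound to an amine nitrogen in a ring. The remainder of the molecule is unchanged.

One measured step alters the group on the same ring nitrogen and so bears directly on this change: a 1.0-fold lower number from compound 1 to compound 3 (0.01 log units; within the scatter). There the whole 2-hydroxy-3-phenylpropyl group was exchanged for a quite different one and the number did not move beyond the scatter. Compound 4 makes another exchange at that same nitrogen while leaving everything else intact, so a step of similar size, that is none beyond the scatter, is expected: a 1.0-fold lower number from compound 1 to compound 4 (0.01 log units; within the scatter). Compound 4 is therefore estimated to give 300 nM in this assay, with a plausible range from 120 nM to 750 nM.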

Compound 4, inhibition constant: 205 nM
Beside the measured number, compound 4's estimate is 1.5-fold (0.17 log units) above it; the range from low to high includes it.
By their numbers in this assay, from the lowest: compounds 4, 3, 1 and 2 (each within the scatter of the next).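

Compound 4 brings a third kind of group to the ring nitrogen, and in this assay it stays within the scatter of both earlier ones: a 1.5-fold lower number from compound 1 to compound 4 (0.18 log units; within the scatter), and a 1.5-fold lower number from compound 3 to compound 4 (0.17 log units; within the scatter) of this assay. Compounds 1, 3 and 4 therefore show that 2-hydroxy-3-phenylpropyl, (1-benzofuran-2-yl)carbonyl and (1H-indol-2-yl)methyl all read alike here, so neither the hydroxyl-bearing chain of compound 1 nor the carbonyl of compound 3 is needed to keep the number in this range, and the new step adds that a bicyclic group joined through a single saturated carbon serves as well. No measurement is available to explain why these different groups give such similar numbers.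

On these data alone, all three groups at this nitrogen carry an aromatic ring, so it remains open whether the number would hold with a small methyl group, or with a carboxylic acid or an amine at the end of a longer chain. As far as these compounds go, it is also open whether the same indifference to the group on this nitrogen would persist if the shared core were altered elsewhere.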